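Changing the amine ring of compound 2

The source may report more compounds than this note shows. Statements on the series, on what has been measured and on what is new or still open speak of the compounds shown alone.

Among the measured compounds shown here, in a functional assay on V79 cells (Cricetulus griseus) for cytotoxicity, read by colony formation (on this read-out lower numbers stand for stronger inhibition and higher numbers for weaker inhibition), compound 2 `O=C(O)c1cn(C2CC2)c2c(Cl)c(N3CCNCC3)c(F)cc2c1=O` gives 43 ug/mL, the second highest of the three numbers measured so far. Compound 1 `CC1(CN)CCN(c2c(F)cc3c(=O)c(C(=O)O)cn(C4CC4)c3c2Cl)C1` lies lower at 8 ug/mL, and compound 3 `O=C(O)c1cn(C2CC2)c2c(C(F)(F)F)c(N3CCNCC3)c(F)cc2c1=O` lies much higher at 1650 ug/mL.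

The next compound to consider is compound 4 `NC1CCN(c2c(F)cc3c(=O)c(C(=O)O)cn(C4CC4)c3c2Cl)CC1`. It keeps the shared core of compound 2, including the chloro group, and differs in one place: 4-aminopiperidin-1-yl in place of piperazin-1-yl on an aromatic carbon. In words, 4-aminopiperidin-1-yl takes the place of piperazin-1-yl on an aromatic carbon.

The step that bears most directly on this change involves the same group: a 5.4-fold higher number from compound 1 to compound 2 (0.73 log units; beyond the scatter), a modest step, with piperazin-1-yl in place of 3-(aminomethyl)-3-methylpyrrolidin-1-yl. The other step, a 38-fold higher number from compound 2 to compound 3 (1.58 log units; beyond the scatter), is large, but it replaces chloro with trifluoromethyl, a change that compound 4 does not make.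

For the measured compounds named here, no measured compound carries 4-aminopiperidin-1-yl, so any forecast is uncertain. Still, compound 4 has an amine-bearing group on its ring, much as compound 1 at 8 ug/mL does, which points towards a lower number. The expected change is modest: a 2.9-fold lower number from compound 2 to compound 4 (0.46 log units; beyond the scatter). For compound 4 the estimated value is 15 ug/mL, with an expected range from 4 ug/mL to 60 ug/mL.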

Compound 4, half-maximal inhibitory concentration: 18 ug/mL
Compound 4: middle estimate off by 1.2-fold (0.08 log units), on the low side; the range from low to high includes it.
By their numbers in this assay, from the lowest: compound 1; then compound 4; then compound 2; then compound 3.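

The 4-aminopiperidin-1-yl group gives a second replacement for piperazin-1-yl at this position, on an aromatic carbon ortho to the chloro group, and a 2.4-fold lower number from compound 2 to compound 4 (0.38 log units; beyond the scatter) in this assay shows that piperazin-1-yl is not the only six-membered ring that can sit here. Among the three compounds that differ only in this group, piperazin-1-yl gives the highest number, and both groups carrying an amino or aminomethyl substituent give lower numbers, with no compound among the three going against this. These two groups are not interchangeable, since a 2.3-fold higher number from compound 1 to compound 4 (0.35 log units; beyond the scatter) is also beyond the usual scatter, but nothing available explains why the three groups differ.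

A hydroxyl group in place of the amino group of 4-aminopiperidin-1-yl, or an aminomethyl chain on the same ring, would test whether the amine itself or its distance from the ring goes with the lower number. Going by these compounds, it also remains open whether the large rise seen with trifluoromethyl in place of chloro, a 38-fold higher number from compound 2 to compound 3 (1.58 log units; beyond the scatter), would recur with 4-aminopiperidin-1-yl in place.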